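Removing the Chloro from the Benzyl Amide

This account rests on a few compounds, and the source may have more. Where it says the series, first, only, none or still open, it means among the compounds named here.

Compound 1 `O=C(CCSc1nnc(-c2ccncc2)s1)Nc1ccc(Cl)cc1`: 8210 nM in an ADME assay on BHK-21 cells (Mesocricetus auratus) for cytotoxicity, with a stated time of 3 days; a higher number here means that more compound is tolerated, a lower number that less compound is tolerated.
Compound 2 `O=C(CCSc1nnc(-c2ccncc2)s1)Nc1c(Cl)cccc1Cl`: 10300 nM.
Compound 3 `O=C(CCSc1nnc(-c2ccncc2)s1)NCc1ccccc1Cl`: > 50000 nM, a limit of the assay rather than a number.

Compound 3 stands highest among the three measured values, and its reading is the limit of > 50000 nM in this assay, at which 1 of the 3 values shown sits. The step of an at least 6.0-fold higher number from compound 1 to compound 3 (0.78 log units; beyond the scatter) reaches that limit. So does the step of an at least 4.8-fold higher number from compound 2 to compound 3 (0.68 log units; beyond the scatter). Between the two phenyl amides, a 1.3-fold higher number from compound 1 to compound 2 (0.10 log units; within the scatter).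

Compound 4 `O=C(CCSc1nnc(-c2ccncc2)s1)NCc1ccccc1` has not yet been measured. It differs from compound 3 by hydrogen in place of chloro on an aromatic carbon. Among the measured compounds shown here, none of the measured steps removes a single chloro from an aromatic ring: the two steps that involve compound 3 exchange the whole group on the amide-type nitrogen, and the one step that keeps an aryl group stays within the scatter. A change of one chlorine is small against those exchanges, so no step beyond the scatter is expected in this assay, and compound 4 is expected to sit at or near the same limit as compound 3. The estimate for compound 4 is 50000 nM, with a range from 20000 nM to 120000 nM, which means an expected step of a number no higher from compound 3 to compound 4 (the limit leaves the size open).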

Compound 4, half-maximal cytotoxic concentration: 18700 nM
Compound 4: middle estimate off by 2.7-fold (0.43 log units), on the high side, outside the stated range (below it).
By their numbers in this assay, from the lowest: compounds 1, 2 and 4 (each within the scatter of the next, the first and the last beyond it). At a limit, above all of these: compound 3.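

In this assay, among the compounds shown here, the single exchange of chloro for hydrogen, on an aromatic carbon ortho to a large group, gives an at least 2.6-fold lower number from compound 3 to compound 4 (0.42 log units; beyond the scatter) and so lies beyond the scatter, which makes it the first measured step that touches only one chlorine. Compound 3 carries a limit and not a number, so this step fixes only a minimum and leaves its true size open: the limit of > 50000 nM in this assay, at which 1 of the 4 values shown sits. Without the chloro, the benzyl amide no longer stands clear of both phenyl amides, since a 2.3-fold higher number from compound 1 to compound 4 (0.36 log units; beyond the scatter) remains beyond the scatter as a modest step, while a 1.8-fold higher number from compound 2 to compound 4 (0.26 log units; within the scatter) stays within it.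

As far as these compounds go, it remains open whether chloro matters only at this carbon or would do the same elsewhere on the benzyl ring, and whether fluoro, methyl or methoxy at this carbon would read as compound 3 does. Also open, from the compounds shown here alone, is how a longer chain between the amide nitrogen and the ring, or an amine or a carboxylic acid on that ring, would read in this assay.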